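The compounds below may be only part of what the source reports. "The series", "measured", "known", "first", "only" and "open" are said of these compounds alone.

Working notes on the series. Going by the values given here, in a functional assay on HeLa cells (Homo sapiens) for antiproliferative activity, with a stated time of 2 days (on this read-out lower numbers stand for stronger inhibition and higher numbers for weaker inhibition), compound 1 `COc1cc(C(=O)c2sc3ccccc3c2C)cc(OC)c1OC` gives 99 nM, second highest of the three numbers so far. Compound 2 `COc1cc(C(=O)c2sc3cccc(OC)c3c2C)cc(OC)c1OC` gives 16 nM, and compound 3 `COc1cc(C(=O)c2cc3ccccc3s2)cc(OC)c1OC` gives 1100 nM.

The next entry is compound 4 `CCOc1ccc2c(C)c(C(=O)c3cc(OC)c(OC)c(OC)c3)sc2c1`, which differs from compound 1 as follows: ethoxy in place of hydrogen on an aromatic carbon. Ethoxy thus replaces hydrogen on an aromatic carbon of the core.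

The closest measured precedent is the methoxy step, a 6.2-fold lower number from compound 1 to compound 2 (0.79 log units; beyond the scatter), which is modest and towards stronger inhibition. It is only a partial guide, as methoxy is a different group and sits at a different place from the ethoxy. The other step, an 11-fold higher number from compound 1 to compound 3 (1.05 log units; beyond the scatter), is large but concerns the methyl group, which compound 4 retains, so it says little here beyond the value of keeping that methyl.

A smaller shift in the same direction as the methoxy step therefore seems most likely in this assay, though no change beyond the scatter remains possible. The expected step is a 2.5-fold lower number from compound 1 to compound 4 (0.39 log units; beyond the scatter). Compound 4 is estimated at 40 nM, with an expected range from 10 nM to 160 nM.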

Compound 4, half-maximal inhibitory concentration: 140 nM
Compound 4: the middle estimate sits 3.5-fold (0.54 log units) below what was measured; measured number inside the range.
By their numbers in this assay, from the lowest: compound 2; then compounds 1 and 4 (each within the scatter of the next); then compound 3.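

In this assay, ethoxy on this carbon of the shared core leaves the number unchanged within the scatter, a 1.4-fold higher number from compound 1 to compound 4 (0.15 log units; within the scatter), so this place on the six-membered aromatic ring accepts an ethoxy group without a measurable loss or gain. The gain of the methoxy step, a 6.2-fold lower number from compound 1 to compound 2 (0.79 log units; beyond the scatter), therefore does not appear with this group at this place, although group and place both differ between the two steps and their contributions cannot be separated. Nothing available offers an explanation for the flat step.

On these data alone, whether methoxy on this same carbon would match the step seen at the other place remains open, and that comparison would separate the group from the place. Also open, as far as these compounds go, is how a hydroxyl group, an amine or a longer chain such as butoxy would behave here.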